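The compounds below may be only part of what the source reports. "The series", "measured", "known", "first", "only" and "open" are said of these compounds alone.

Measured so far:
- Compound 1, `CSc1nc(-c2ccccc2)c(C#N)c(N2CCN(c3ccnc4cc(Cl)ccc34)CC2)n1`: in an ADME assay on CCRF-CEM cells (Homo sapiens) for inhibition, read by cell counting (on this read-out lower numbers stand for stronger inhibition and higher numbers for weaker inhibition), compound 1 gives > 250000 nM.
- Compound 2, `CSc1nc(NCCCCNc2ccnc3cc(Cl)ccc23)c(C#N)c(-c2ccc([N+](=O)[O-])cc2)n1`: in this assay compound 2 gives 760 nM.

Compound 1 reaches only the limit of this assay, at which (the limit of > 250000 nM in this assay, at which 1 of the 2 values shown sits). Among the compounds with values here, compound 2 therefore stands as the only real number in this assay; the other value shown is a limit and not a number, so the two cannot be compared as a step.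

Compound 3, `COc1cc(-c2nc(SC)nc(NCCCCNc3ccnc4cc(Cl)ccc34)c2C#N)cc(OC)c1OC`, is not yet measured. It differs from compound 2 in one place: 3,4,5-trimethoxyphenyl in place of 4-nitrophenyl on an aromatic carbon. The shared core, the nitrile, the methylsulfanyl group and the chain to the other ring stay as they are. Within the data shown here, no measured step for a change of this kind is available, so the expectation rests on compound 2 alone. The step from compound 2 to compound 3 is expected to be small, a 1.3-fold higher number from compound 2 to compound 3 (0.12 log units; within the scatter), and may lie within the scatter. For compound 3 in this assay the estimate is 1000 nM, between 200 nM and 5000 nM.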

Compound 3, half-maximal inhibitory concentration: 3600 nM
Compound 3: middle estimate off by 3.6-fold (0.56 log units), on the low side; the measured number falls inside the stated range.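

Within the data shown here, this is the first step that can be read in this assay: placing 3,4,5-trimethoxyphenyl instead of 4-nitrophenyl on this aromatic carbon gives a 4.7-fold higher number from compound 2 to compound 3 (0.68 log units; beyond the scatter). Both groups carry one six-membered aromatic ring of carbon only, so a change in what that ring carries, with the rest of the molecule kept the same, is enough to move the number beyond the usual scatter. Nothing in the data shown explains why the number moves in this direction.

The compounds shown leave open whether a single methoxy group, as in 4-methoxyphenyl, would give a number closer to that of compound 2 or compound 3. They also leave open how a 4-aminophenyl group at this position would read, so this one step cannot yet be generalised to other groups.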